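A few compounds are considered here, and "the series" means these few. Any claim that something is new, unique, unknown or untested is made for them only; others in the source may bear on it.

Compound 1 `COc1ccc(/C=C(/SCc2ccc(Cl)cc2)C(=O)c2ccc(Br)cc2)cc1`: 10000 nM
Compound 2 `Cc1ccsc1/C=C(/SCc1ccc(Cl)cc1)C(=O)c1ccc(Cl)cc1`: 50000 nM
Compound 3 `O=C(/C(=C\c1cccc(Cl)c1Cl)SCc1ccc(Cl)cc1)c1ccc(Cl)cc1`: 10000 nM

In a functional assay on DU-145 cells (Homo sapiens) for inhibition, read by trypan blue exclusion, with a stated time of 96 h (a lower number here means a stronger inhibitor of growth, a higher number a weaker inhibitor of growth), compound 3 gives 10000 nM, which is level with compound 1 at the digits shown, and the two together sit at the lowest number of the three measured compounds. The furthest of them is compound 2, which gives 50000 nM; the one change listed between these two, a 5.0-fold lower number from compound 2 to compound 3 (0.70 log units; beyond the scatter), is the only measured step at the position now in question.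

Compound 4 `COc1ccc(/C=C(/SCc2ccc(Cl)cc2)C(=O)c2ccc(Cl)cc2)cc1` is reached from compound 3 by one change: 4-methoxyphenyl in place of 2,3-dichlorophenyl on a double-bonded chain carbon bound to a double-bonded chain carbon. Among the measured compounds shown here, the same step in the measured set, the one from compound 2 to compound 3, went in the direction of a lower number and was modest in size. For compound 4 the more direct guide is compound 1, which carries the same 4-methoxyphenyl on the chain and gives 10000 nM in this assay, a value that does not differ at the digits shown from compound 3. The step from compound 3 to compound 4 is therefore expected to be no change at the digits printed from compound 3 to compound 4 (within the scatter), that is, nothing beyond the scatter. Compound 4 is expected to give 10000 nM in this assay, with a range from 4000 nM to 25000 nM.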

Compound 4, concentration for 50% growth inhibition: 10000 nM
For compound 4 middle estimate and measured number coincide at the digits printed; measured number inside the range.
By their numbers in this assay, from the lowest: compounds 1, 3 and 4 (each within the scatter of the next); then compound 2.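

In this assay, the exchange of 2,3-dichlorophenyl for 4-methoxyphenyl on the double-bonded chain carbon gives no change at the digits printed from compound 3 to compound 4 (within the scatter), so these two differently substituted phenyl groups cannot be told apart at this position, while 3-methylthiophen-2-yl now stands apart from a second phenyl group, with a 5.0-fold lower number from compound 2 to compound 4 (0.70 log units; beyond the scatter). Among the compounds shown here, the comparison of compound 1 and compound 4 adds a second place to the picture: chloro in place of bromo on an aromatic carbon gives no change at the digits printed from compound 1 to compound 4 (within the scatter), so this halogen exchange leaves the number level in the one pair that can be read. Nothing available here offers an explanation for either the level values or the gap to compound 2.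

The compounds shown leave open whether the gap to compound 2 follows the thiophene ring or its methyl group, which a plain thiophen-2-yl at the same chain carbon would help to separate. They also leave open whether a phenyl group bearing an amine or a carboxylic acid would stay at the level shared by compound 1, compound 3 and compound 4.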